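The source may hold more compounds than are shown below. What is called first, only, known or untested is meant among the compounds shown, and "the series" means these compounds.

Measured in an ADME assay on WI-38 cells (Homo sapiens) for cytotoxicity, read by MTT assay, with a stated time of 72 h; on this read-out lower numbers stand for stronger inhibition and higher numbers for weaker inhibition:
- compound 1 `COc1ccc(NC(=O)CCc2cccc3c2B(O)OC3)cc1`: > 100000 nM
- compound 2 `C#Cc1cccc(NC(=O)CCc2cccc3c2B(O)OC3)c1`: > 100000 nM
- compound 3 `COc1ccc(NC(=O)CCc2cccc3c2B(O)OC3)cc1OC`: > 100000 nM

Within the data shown here, the position so far is the limit of > 100000 nM in this assay, at which 3 of the 3 values shown sit. Compound 2 gives > 100000 nM, which is a limit and not a number.

Next is compound 4 `COc1cc(OC)cc(-c2cccc(NC(=O)CCc3cccc4c3B(O)OC4)c2)c1`, with the change (3,5-dimethoxyphenyl in place of ethynyl on an aromatic carbon). Among the measured compounds shown here, the one measured step is a step that the two limits leave unreadable from compound 1 to compound 3, so it offers no size to carry over. Compound 3 has two methoxy groups and gives > 100000 nM, also a limit.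

In this assay, only a small move toward stronger inhibition is expected, if any. The estimated change is an at least 1.2-fold lower number from compound 2 to compound 4 (0.09 log units; that floor lies within the scatter). Compound 4 is estimated at 80000 nM, within a range of 25000 nM to 150000 nM.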

Compound 4, half-maximal inhibitory concentration: 1700 nM
Estimate against measurement, compound 4: 47-fold (1.67 log units) above; measured number below the stated range.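

In this assay, 3,5-dimethoxyphenyl in place of ethynyl on this aromatic carbon gives an at least 58-fold lower number from compound 2 to compound 4 (1.76 log units; beyond the scatter), the first step in the series with a readable size; the other step shown cannot be read. Compound 4 is the only compound shown with a measured number and not a limit: the limit of > 100000 nM in this assay, at which 3 of the 4 values shown sit.

On these data alone, compound 2 has only a limit, so the full size of the step stays open. Also open, as far as these compounds go, is whether the step belongs to the added aromatic ring or its two methoxy groups, and how a phenyl carrying an amine or a carboxylic acid in their place would read.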